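Adding one fluoro to compound 2

The source may hold more compounds than are shown below. What is called first, only, known or untested is meant among the compounds shown, and "the series" means these compounds.

compound 1 `COc1ccc(-n2c(=O)c(C(=O)Nc3ccc(Oc4ncnc5c4ccn5C)cc3)cc3cccnc32)cc1`: 65800 nM
compound 2 `Cn1ccc2c(Oc3ccc(NC(=O)c4cc5cccnc5n(-c5ccc(C(F)(F)F)cc5Cl)c4=O)cc3)ncnc21`: 174000 nM
compound 3 `Cn1ccc2c(Oc3ccc(NC(=O)c4cc5cccnc5n(-c5ccc(C(F)(F)F)c(Cl)c5)c4=O)cc3)ncnc21`: 289000 nM

These numbers come from a functional assay on HeLa cells (Homo sapiens) for cytotoxicity, read by MTT assay, with a stated time of 72 h; a higher number here means a weaker inhibitor, a lower number a stronger inhibitor. All three are large, so none of these compounds inhibits strongly here. Compound 2, at 174000 nM, cannot be told apart from compound 3, as the data show a 1.7-fold higher number from compound 2 to compound 3 (0.22 log units; within the scatter). Compound 1 stands clearly lower, with a 2.6-fold higher number from compound 1 to compound 2 (0.42 log units; beyond the scatter).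

The next compound is compound 4 `Cn1ccc2c(Oc3ccc(NC(=O)c4cc5cccnc5n(-c5ccc(C(F)(F)F)cc5Cl)c4=O)cc3F)ncnc21`, which differs from compound 2 at one spot: fluoro in place of hydrogen on an aromatic carbon.

Among the measured compounds shown here, all the measured steps change the group on an aromatic nitrogen, and the largest, a 4.4-fold higher number from compound 1 to compound 3 (0.64 log units; beyond the scatter), is only modest. For the measured compounds named here, none of them touches the ring that takes the fluoro, so the data offer no direct precedent for this change. Swapping a whole group moved the number only modestly, so a single fluoro is expected to produce no step beyond the scatter in this assay. The estimated step is a 1.0-fold lower number from compound 2 to compound 4 (0.01 log units; within the scatter). The estimate for compound 4 is 170000 nM, with the value expected between 70000 nM and 400000 nM.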

Compound 4, half-maximal inhibitory concentration: 170000 nM
Beside the measured number, compound 4's estimate shows no gap at the digits printed, and the stated range covers the measured number.
By their numbers in this assay, from the lowest: compound 1; then compounds 4, 2 and 3 (each within the scatter of the next).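

Until this point, every measured step had changed the group on the aromatic nitrogen, so nothing showed how the rest of the molecule responds to change. In this assay, among the compounds shown here, fluoro in place of hydrogen gives a 1.0-fold lower number from compound 2 to compound 4 (0.01 log units; within the scatter) and so provides the first measured reading for this six-membered aromatic ring of carbon only: at this position, ortho to a large group and meta to a large group, adding this one atom leaves the number within the scatter. No measurement shown here gives a reason for this result.

At this position the compounds shown carry only hydrogen or fluoro, so it remains open whether an amine or a carboxylic acid there would also leave the number within the scatter, or would instead move it clearly. Also open, from the compounds shown here alone, is whether the same fluoro would behave in this way alongside the 4-methoxyphenyl group of compound 1, which has a clearly lower number than compound 2 and may respond differently to the change.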